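The source may hold more compounds than are shown below. What is called first, only, known or untested is meant among the compounds shown, and "the series" means these compounds.

Measured so far:
- compound 1, `N#Cc1ccc(NC(=O)c2cc(-c3ccncc3)ccc2O)cc1`: 5410 nM
- compound 2, `Cc1cc(C#N)ccc1NC(=O)c1ccc2cccnc2c1O`: 710 nM

In a functional assay on HL-60 cells (Homo sapiens) for cytotoxicity, read by luminescence and CellTiter-Glo, with a stated time of 3 days (a lower number here means a stronger inhibitor, a higher number a weaker inhibitor), compound 1 gives 5410 nM, the higher of the two numbers in hand. Compound 2 gives 710 nM in this assay, and the gap between the two lies beyond the usual scatter. The two structures differ in several places at once, so nothing can be drawn from that gap about any single change.

The next compound is compound 3, `Cc1ccc(O)c(C(=O)Nc2ccc(C#N)cc2)c1`, not yet measured in this assay. Compared with compound 1 the change is methyl in place of pyridin-4-yl on an aromatic carbon. The whole of the pyridin-4-yl is removed and only a methyl is left in its place.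

Among the measured compounds shown here, no pair of measured compounds shows this change on its own, and compound 2 carries its methyl on a different ring and a different core, so it gives no guide to the step. The expectation for the step from compound 1 to compound 3 is therefore a 1.1-fold higher number from compound 1 to compound 3 (0.04 log units; within the scatter), with no direction beyond the scatter claimed.

For compound 3 the estimate in this assay is 6000 nM, with a range of 1500 nM to 25000 nM.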

Compound 3, half-maximal inhibitory concentration: 3920 nM
Compound 3: the middle estimate sits 1.5-fold (0.18 log units) above what was measured; measured number inside the range.
By their numbers in this assay, from the lowest: compound 2; then compounds 3 and 1 (each within the scatter of the next).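

In this assay, the exchange of pyridin-4-yl for methyl on this aromatic carbon, para to a hydroxy group, gives a 1.4-fold lower number from compound 1 to compound 3 (0.14 log units; within the scatter). At this position, therefore, the whole pyridin-4-yl, with its six-membered aromatic ring and its hydrogen-bond acceptor, can give way to a single methyl without a shift beyond the scatter, so this pair gives no sign that the reading depends on the pyridin-4-yl. No measurement on these compounds speaks to why the step is this small.

From the compounds shown here alone, with only these two groups at this carbon, it remains open whether the flat step extends to other kinds of substituent, and an amine, a carboxylic acid or a longer chain such as n-butyl in the same place would each test that. Compound 2, at 710 nM, differs from compound 1 and compound 3 in several places at once, so its steps to them cannot be read and its number says nothing about this position.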